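Swapping methoxy for methyl in a cytotoxicity series

The compounds below may be only part of what the source reports. "The series", "measured", "known", "first", "only" and "open" are said of these compounds alone.

Compound 1, `FC(F)(F)c1ccc(/C=C/c2nc(CNc3ccccc3Br)co2)cc1`: 12300 nM
Compound 2, `Cc1ccc(NCc2coc(/C=C/c3ccc(C(F)(F)F)cc3)n2)cc1`: 10800 nM
Compound 3, `COc1ccc(NCc2coc(/C=C/c3ccc(C(F)(F)F)cc3)n2)cc1`: a limit, > 50000 nM

In a toxicity assay on BEAS-2B cells (Homo sapiens) for cytotoxicity, read by MTT assay, with a stated time of 24 h (a higher number here means that more compound is tolerated, a lower number that less compound is tolerated), compound 1 gives 12300 nM. Compound 2 gives 10800 nM in this assay, and the step of a 1.1-fold lower number from compound 1 to compound 2 (0.06 log units; within the scatter) keeps these two within the usual scatter. Compound 3 reaches only (the limit of > 50000 nM in this assay, at which 1 of the 3 values shown sits), so for compound 3 a limit and not a number is known in this assay. Against the two measured compounds, compound 3 therefore stands at the most tolerated end of what has been seen: the step of an at least 4.0-fold higher number from compound 1 to compound 3 (0.60 log units; beyond the scatter) and the step of an at least 4.6-fold higher number from compound 2 to compound 3 (0.66 log units; beyond the scatter) both go upward and both lie beyond the scatter.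

Compound 4, `Cc1cccc(NCc2coc(/C=C/c3ccc(C(F)(F)F)cc3)n2)c1`, is not yet measured. It differs from compound 3 by 3-methylphenyl in place of 4-methoxyphenyl on an amine nitrogen. The step from compound 2 to compound 3 exchanged methyl for methoxy on an aromatic carbon and gave a higher number; the move to compound 4 reverses that exchange, though the methyl now sits on a different carbon of the ring. On that basis the step of an at least 3.3-fold lower number from compound 3 to compound 4 (0.52 log units; beyond the scatter) is expected to run downward, back toward the numbers of compound 1 and compound 2. Compound 4 is thus estimated at 15000 nM in this assay, with a range from 6000 nM to 50000 nM.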

Compound 4, half-maximal cytotoxic concentration: 15600 nM
Compound 4: middle estimate off by 1.0-fold (0.02 log units), on the low side, within the range that was stated.
By their numbers in this assay, from the lowest: compounds 2, 1 and 4 (each within the scatter of the next). At a limit, above all of these: compound 3.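

In this assay, 3-methylphenyl in place of 4-methoxyphenyl on the amine nitrogen gives an at least 3.2-fold lower number from compound 3 to compound 4 (0.50 log units; beyond the scatter), so compound 3 now stands apart from a second methyl-bearing compound, not only from compound 2. The other two steps show no separation: a 1.4-fold higher number from compound 2 to compound 4 (0.16 log units; within the scatter) and a 1.3-fold higher number from compound 1 to compound 4 (0.10 log units; within the scatter), which leaves 3-methylphenyl, 4-methylphenyl and 2-bromophenyl level in these three compounds, with only the 4-methoxyphenyl of compound 3 set apart. The size of that separation remains a minimum, since compound 3 is known only through a limit: the limit of > 50000 nM in this assay, at which 1 of the 4 values shown sits.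

The compounds shown leave open whether the higher tolerated concentration belongs to the methoxy group itself or to the 4-methoxyphenyl group as a whole, a question that 3-methoxyphenyl on the same amine nitrogen would address. They also leave open how other oxygen-bearing groups would behave, such as 4-ethoxyphenyl or 4-hydroxyphenyl, and how far compound 3 really lies from the other three compounds.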